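Cyclohexyl for 3-Methoxyphenyl on Two Different Cores

This account rests on a few compounds, and the source may have more. Where it says the series, first, only, none or still open, it means among the compounds named here.

Measured in a functional assay on MCF7 cells (Homo sapiens) for antiproliferative activity, read by MTT assay, with a stated time of 72 h; a higher number here means a weaker inhibitor, a lower number a stronger inhibitor:
compound 1 `COc1cccc(N2C(=O)COc3ccc(-c4cnc(OC)c(NS(=O)(=O)c5ccc(F)cc5)c4)cc32)c1`, a limit of the assay: > 40000 nM
compound 2 `COc1ncc(-c2ccc3c(c2)N(C2CCCCC2)C(=O)CO3)cc1NS(=O)(=O)c1ccc(F)cc1`: 30100 nM
compound 3 `COc1cccc(N2C(=O)COc3ccc(-c4cnc5ccccc5c4)cc32)c1`, a limit of the assay: > 40000 nM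

The change cyclohexyl in place of 3-methoxyphenyl on an amide-type nitrogen in a ring made the step of an at least 1.3-fold lower number from compound 1 to compound 2 (0.12 log units; that floor lies within the scatter) in this assay, and this sits against (the limit of > 40000 nM in this assay, at which 2 of the 3 values shown sit). How the core of compound 1 and the core of compound 3 differ is not broken down here. Compound 4 `O=C1COc2ccc(-c3cnc4ccccc4c3)cc2N1C1CCCCC1` carries the same change on the core of compound 3, namely (cyclohexyl in place of 3-methoxyphenyl on an amide-type nitrogen in a ring). In this assay compound 4 is expected to move by an at least 1.1-fold lower number from compound 3 to compound 4 (0.05 log units; that floor lies within the scatter), because an at least 1.3-fold lower number from compound 1 to compound 2 (0.12 log units; that floor lies within the scatter) was itself within the scatter and started from a limit. Compound 4 is therefore estimated at 35000 nM, between 15000 nM and 60000 nM, with a fair chance that only a limit is reported.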

Compound 4, half-maximal inhibitory concentration: > 40000 nM
Compound 4 gave a limit, no number (the forecaster's own chance of this, stated with the estimate: 55%); middle value at least 1.1-fold (0.05 log units) from the limit.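

Compound 3 and compound 4 both give only a limit of the assay in this assay, so the step between them cannot be read. The compounds shown leave open whether cyclohexyl in place of 3-methoxyphenyl changes activity on the core of compound 3, and most values offer no number: the limit of > 40000 nM in this assay, at which 3 of the 4 values shown sit.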